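A few compounds are considered here, and "the series" means these few. Any claim that something is new, unique, unknown or untested is made for them only; others in the source may bear on it.

Two compounds share one core and differ only in a single group on a five-membered aromatic ring. Compound 1 `c1ccc2oc(-c3cn4nc(C5CC5)sc4n3)cc2c1` carries a cyclopropyl there, and compound 2 `COc1nn2cc(-c3cc4ccccc4o3)nc2s1` carries a methoxy. In an assay for antagonist activity at proteinase-activated receptor 4 (Homo sapiens), with stated times of 5 min, 50 s and 15 min, in the presence of a further agent that is not named here (on this read-out lower numbers stand for stronger inhibition and higher numbers for weaker inhibition), compound 1 gives > 30000 nM, which is a limit of the assay and not a number. In this assay compound 2 gives 240 nM. Among the measured compounds shown here, the one measured step, an at least 120-fold lower number from compound 1 to compound 2 (2.09 log units; beyond the scatter), can only be given as a bound because compound 1 sits at the limit of > 30000 nM in this assay, at which 1 of the 2 values shown sits. Compound 2 thus holds the only actual number shown, the other value being a limit.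

Compound 3 `Cc1nn2cc(-c3cc4ccccc4o3)nc2s1` has not yet been measured. It differs from compound 2 by methyl in place of methoxy on an aromatic carbon. The measured step bears only loosely on this change: it shows that methoxy in place of cyclopropyl gives a far lower number, but not how methyl compares with methoxy. Since everything else in compound 2 stays the same, a step of modest size is expected, towards a weaker result, and a 2.5-fold higher number from compound 2 to compound 3 (0.40 log units; beyond the scatter) is the estimated step. Compound 3 is therefore expected to give 600 nM in this assay, with a range from 150 nM to 3000 nM.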

Compound 3, half-maximal inhibitory concentration: > 30000 nM
Compound 3 was reported as a limit; the forecaster's own chance of this, stated with the estimate: 10%; at least 50-fold (1.69 log units) between middle value and limit.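

In this assay, replacing methoxy with methyl on this carbon, which sits next to the ring nitrogen and next to the ring sulfur, gives an at least 120-fold higher number from compound 2 to compound 3 (2.09 log units; beyond the scatter). The earlier pair compared methoxy only with cyclopropyl, and it could not show whether that result was special to cyclopropyl; now a second group, the small methyl, also loses the measurable inhibition, so among the three groups shown only methoxy gives an actual number. The step between compound 1 and compound 3 cannot be read, because each of these two values is a limit of the assay and not a number: the limit of > 30000 nM in this assay, at which 2 of the 3 values shown sit.

Still open, going by these compounds, is which feature of methoxy matters, whether its oxygen or something else about the group, and whether another group on this carbon, such as an ethoxy, a hydroxyl or an amine, would give a number close to that of compound 2. Also open, on these data alone, is how much weaker compound 1 and compound 3 really are, and whether the two differ from each other at all.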